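Swapping an aromatic ester for a simple acetate

A few compounds are considered here, and "the series" means these few. Any claim that something is new, unique, unknown or untested is made for them only; others in the source may bear on it.

Compound 2 `CC(=O)Oc1ccccc1C(=O)O[C@H]1CO[C@H]2[C@@H]1OC[C@H]2OC(=O)c1ccnn1C` has the higher of the two numbers recorded so far in an ADME assay on a cell-free system (plasma, Homo sapiens) for metabolic stability, with Plasma (Rattus norvegicus) as the target, read by HPLC, at pH 7.4 (on this read-out lower numbers stand for a shorter-lived compound and higher numbers for a longer-lived compound), where compound 2 gives 0.0642 h. Among the compounds with values here, its only measured neighbour is compound 1 `CC(=O)Oc1ccccc1C(=O)O[C@H]1CO[C@H]2[C@@H]1OC[C@H]2OC(=O)c1snnc1C`, which in this assay gives 0.0065 h; the step of a 9.9-fold higher number from compound 1 to compound 2 (0.99 log units; beyond the scatter) came from exchanging one five-membered aromatic group for another on the carbonyl carbon. Compound 3 `CC(=O)Oc1ccccc1C(=O)O[C@H]1CO[C@H]2[C@@H]1OC[C@H]2OC(C)=O` changes that same carbonyl carbon again, but now to a much smaller group (methyl in place of 1-methyl-1H-pyrazol-5-yl on a carbonyl carbon). Within the data shown here, no measured step involves a methyl at this place, so the one known step only shows that the group on this carbonyl carbon matters. Among the measured compounds shown here, with no direct precedent, a step of a 2.1-fold lower number from compound 2 to compound 3 (0.33 log units; beyond the scatter) is expected, most likely small and, if anything, towards a shorter-lived compound. Compound 3 is therefore estimated at 0.03 h in this assay, within a range of 0.007 h to 0.13 h.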

Compound 3, half-life: 0.0095 h
Compound 3: the middle estimate sits 3.2-fold (0.50 log units) above what was measured; the range from low to high includes it.
By their numbers in this assay, from the lowest: compounds 1 and 3 (each within the scatter of the next); then compound 2.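

In this assay the small methyl does not keep the longer half-life seen with 1-methyl-1H-pyrazol-5-yl, giving a 6.8-fold lower number from compound 2 to compound 3 (0.83 log units; beyond the scatter) on this carbonyl carbon. Methyl and 4-methyl-1,2,3-thiadiazol-5-yl cannot be told apart here, with a 1.5-fold higher number from compound 1 to compound 3 (0.16 log units; within the scatter), so a five-membered aromatic ring at this place does not by itself separate a compound from the simple acetate: of these three groups, only 1-methyl-1H-pyrazol-5-yl stands apart. Nothing measured here explains why that group differs from the other two.

Going by these compounds, it remains open whether other rings, such as phenyl or pyridine, would behave like 1-methyl-1H-pyrazol-5-yl or like methyl. A longer chain such as propyl or tert-butyl could also show whether the half-life changes at all among simple carbon groups.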